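Methoxy for Chloro on the Aromatic Ring

The compounds below may be only part of what the source reports. "The series", "measured", "known", "first", "only" and "open" are said of these compounds alone.

Compound 1 `COc1ccc(N)c(C(=O)CCNC(=O)C2CCC2)c1`: 92.2%
Compound 2 `Nc1ccc(Cl)cc1C(=O)CCNC(=O)c1ccccc1`: "not determined" (no result reported)

In a functional assay for inhibition of kynurenine 3-monooxygenase (Rattus norvegicus), tested at 1 mM (a higher number here means more inhibition at the concentration tested (going by the name of the read-out), a lower number less inhibition), compound 1 gives 92.2%. Compound 2 `Nc1ccc(Cl)cc1C(=O)CCNC(=O)c1ccccc1` has no number in this assay, so it stands nowhere on the scale shown. Compound 3 `COc1ccc(N)c(C(=O)CCNC(=O)c2ccccc2)c1` differs from compound 2 by methoxy in place of chloro on an aromatic carbon. With no value for compound 2, no size or direction of step in this assay can be expected from that pair; the estimate rests on compound 1 alone. Compound 3 is expected to give about 88%, within 65% to 100%, because compound 1 gives 92.2% and shares the same methoxy and amino pattern.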

Compound 3, a percentage reported as inhibition, at one concentration (the size of the read-out at that concentration, not a potency): 97.2%
Compound 3: middle estimate off by 9.2 percentage points, on the low side; the range from low to high includes it.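

In this assay, phenyl in place of cyclobutyl on the carbonyl carbon gives a number 5 percentage points higher from compound 1 to compound 3 (within the scatter), so at this position the ring swap leaves the read-out unchanged within the usual scatter. Compound 2 has no number, and the step from chloro to methoxy cannot be read. Nothing measured here offers an explanation for either compound's result. Still open, on these data alone, is how a hydroxy or ethoxy group would read in place of the methoxy, para to an amino group. Also open, as far as these compounds go, is how a longer chain would read in place of phenyl on the carbonyl carbon.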